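Cytotoxicity in Vero cells: a benzamide analogue of compound 3

The source may hold more compounds than are shown below. What is called first, only, known or untested is meant among the compounds shown, and "the series" means these compounds.

Compound 1 `COc1ccc(C(=O)Nc2cc3nc(C4CCCCC4)[nH]c3cc2N2CCCC2)cc1`: > 100 ug/mL
Compound 2 `CCCN(CCC)c1cc2[nH]c(C3CCCCC3)nc2cc1NC(=O)c1ccccc1`: > 100 ug/mL
Compound 3 `CCOCCOC(=O)Nc1cc2nc(C3CCCCC3)[nH]c2cc1N1CCCC1`: > 100 ug/mL

In an ADME assay on Vero cells (Chlorocebus sabaeus) for cytotoxicity, read by resazurin assay, with a stated time of 3 days (on this read-out lower numbers stand for stronger inhibition and higher numbers for weaker inhibition), compound 3 sits at a limit of the assay, > 100 ug/mL, and not at a measured number. The same holds for every value shown: compound 1 gives the limit > 100 ug/mL in this assay. Compound 2 gives the limit > 100 ug/mL in this assay. Going by the values given here, all three share the core of compound 1 with a cyclohexyl group and differ in the amine and in the group on the carbonyl carbon; the only step between two of them that differs in one place, a step that the two limits leave unreadable from compound 1 to compound 3, is left unreadable because both ends stand at the limit of > 100 ug/mL in this assay, at which 3 of the 3 values shown sit.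

Compound 4 `O=C(Nc1cc2nc(C3CCCCC3)[nH]c2cc1N1CCCC1)c1ccccc1` is the benzamide analogue of compound 3: phenyl in place of 2-ethoxyethoxy on a carbonyl carbon. Among the compounds with values here, no measured step bears readably on this change, since every value in this assay is a limit, and the benzamido compound 2 stands at a limit as well. Compound 4 is therefore expected to show a step that the limit leaves unreadable from compound 3 to compound 4, with a limit again the likeliest outcome. The estimate for compound 4 in this assay is 200 ug/mL, within 100 ug/mL to 500 ug/mL.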

Compound 4, half-maximal inhibitory concentration: > 100 ug/mL
Compound 4 was reported as a limit; the forecaster's own chance of this, stated with the estimate: 85%; the middle value is on the limit's open side.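

In this assay the steps to compound 4 from compound 1, compound 2 and compound 3 cannot be read, because both ends of each step stand at a limit: the limit of > 100 ug/mL in this assay, at which 4 of the 4 values shown sit.

The compounds shown leave open how far each of these four lies beyond that limit, and whether any of the changes among them alters cytotoxicity.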